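Swapping the terminal phenyl ring on a shared core

The compounds below may be only part of what the source reports. "The series", "measured", "known", "first", "only" and "open" are said of these compounds alone.

Of the compounds shown here, three built on one core have been tested in an assay for binding affinity to dual specificity mitogen-activated protein kinase kinase 4 (Homo sapiens), read by KINOMEscan, tested at 100 nM; on this read-out lower numbers stand for a stronger effect and higher numbers for a weaker effect at the one concentration tested. Compound 1, `CCCS(=O)(=O)Nc1ccc(F)c(C(=O)c2n[nH]c3ncc(-c4ccc(F)cc4)cc23)c1F`, gives 2.1%. Compound 2, `CCCS(=O)(=O)Nc1ccc(F)c(C(=O)c2n[nH]c3ncc(-c4ccccc4O)cc23)c1F`, carries a 2-hydroxyphenyl in place of the 4-fluorophenyl and gives 9%. Compound 3, `CCCS(=O)(=O)Nc1ccc(F)c(C(=O)c2n[nH]c3ncc(-c4cccc(O)c4)cc23)c1F`, carries a 3-hydroxyphenyl at the same position and gives 2.2%. Compound 1 sits at the lower end of these three numbers, but both its neighbours lie within the usual scatter of it: a number 6.9 percentage points higher from compound 1 to compound 2 (within the scatter), and a number 0.1 percentage points higher from compound 1 to compound 3 (within the scatter). Between the two hydroxyphenyl analogues, a number 6.8 percentage points lower from compound 2 to compound 3 (within the scatter).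

Compound 4, `CCCS(=O)(=O)Nc1ccc(F)c(C(=O)c2n[nH]c3ncc(-c4cc(Cl)cc(Cl)c4)cc23)c1F`, has not yet been measured. It differs from compound 1 only at the terminal ring: 3,5-dichlorophenyl in place of 4-fluorophenyl on an aromatic carbon. Among the compounds with values here, every measured step so far changed this same ring, and none moved the read-out beyond the scatter, so the step to compound 4 is expected to stay small as well. Compound 4 is therefore expected to give about 4% in this assay, within a range of 0.5% to 15%. This corresponds to an expected step of a number 1.9 percentage points higher from compound 1 to compound 4 (within the scatter), which would again fall within the usual scatter.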

Compound 4, a percentage reported as activity, at one concentration (the size of the read-out at that concentration, not a potency): 73%
The estimate for compound 4 lay 69 percentage points below the measured number; measured number outside the range, above it.
By their numbers in this assay, from the lowest: compounds 1, 3 and 2 (each within the scatter of the next); then compound 4.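

In this assay, this position on the shared core proves far from indifferent to the ring it carries: the 3,5-dichlorophenyl gives a number 70.9 percentage points higher from compound 1 to compound 4 (beyond the scatter), along with a number 70.8 percentage points higher from compound 3 to compound 4 (beyond the scatter) and a number 64 percentage points higher from compound 2 to compound 4 (beyond the scatter), all large and beyond the scatter. The three earlier rings gave no hint of this, as the 4-fluorophenyl, 2-hydroxyphenyl and 3-hydroxyphenyl analogues all stayed within the scatter of one another, so a much weaker effect at the one concentration tested first appears here, with a ring that, like the 4-fluorophenyl, has no hydrogen-bond donors or acceptors. Nothing available accounts for the jump, and these compounds cannot show whether it depends on the chlorines themselves or on where they sit on the ring.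

Still open, as far as these compounds go, is how the read-out would respond to a plain phenyl, a chlorophenyl with a single chlorine, or a difluorophenyl, any of which would help separate the kind of substituent from the pattern of substitution. Also open, from the compounds shown here alone, is whether a ring carrying an amine or a carboxylic acid would stay with compounds 1, 2 and 3 or move towards compound 4.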